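The source may hold more compounds than are shown below. What is called first, only, known or untested is meant among the compounds shown, and "the series" means these compounds.

Measured in a functional assay on HeLa cells (Homo sapiens) for antiproliferative activity, read by MTT assay, with a stated time of 48 h; on this read-out lower numbers stand for stronger inhibition and higher numbers for weaker inhibition:
- compound 1 `CCOc1cc(-c2ccc3c(ccn3C)c2)cn2c(-c3cc(OC)c(OC)c(OC)c3)nnc12`: 210 nM
- compound 2 `COc1cc(-c2nnc3c(OC)cc(-c4ccc5c(ccn5C)c4)cn23)cc(OC)c1OC`: 15 nM
- compound 3 `COc1cc(-c2nnc3c(OC4COC4)cc(-c4ccc5c(ccn5C)c4)cn23)cc(OC)c1OC`: 214 nM

Compound 3 shares the high end of these numbers with one other compound, the measured step being a 1.0-fold higher number from compound 1 to compound 3 (0.01 log units; within the scatter). It stands well apart from the remaining compound, with a step of a 14-fold higher number from compound 2 to compound 3 (1.15 log units; beyond the scatter).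

Compound 4 `COc1cc(-c2nnc3c(OCC(F)(F)F)cc(-c4ccc5c(ccn5C)c4)cn23)cc(OC)c1OC` carries 2,2,2-trifluoroethyl in place of oxetan-3-yl on an oxygen on an aromatic ring. The group on this oxygen can clearly matter in this assay, as the step of a 14-fold lower number from compound 1 to compound 2 (1.15 log units; beyond the scatter) shows. Only the methyl-bearing compound 2 stands apart, however, while ethyl and oxetan-3-yl give matching numbers. The closest measured group to the entering chain is the ethyl of compound 1, at 210 nM. Within the data shown here, no measured compound carries fluorine, so this comparison remains uncertain. The expected step is a 1.1-fold lower number from compound 3 to compound 4 (0.03 log units; within the scatter), so no change beyond the scatter is anticipated. The estimate for compound 4 is 200 nM, with an expected range of 70 nM to 600 nM.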

Compound 4, half-maximal inhibitory concentration: 199 nM
Beside the measured number, compound 4's estimate is 1.0-fold (0.00 log units) above it, and the stated range covers the measured number.
By their numbers in this assay, from the lowest: compound 2; then compounds 4, 1 and 3 (each within the scatter of the next).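

In this assay the 2,2,2-trifluoroethyl group falls in with ethyl and oxetan-3-yl on the oxygen on the aromatic ring: a 1.1-fold lower number from compound 3 to compound 4 (0.03 log units; within the scatter) and a 1.1-fold lower number from compound 1 to compound 4 (0.02 log units; within the scatter) both stay within the scatter, so trifluoromethyl in place of methyl on the saturated chain carbon leaves no readable change. Fluorine, absent from the earlier compounds, therefore separates nothing among these three, while a 13-fold higher number from compound 2 to compound 4 (1.12 log units; beyond the scatter) leaves methyl as the only one of the four groups on this oxygen that stands apart. Nothing among the data shown explains why methyl alone differs.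

The compounds shown leave open how a simple hydroxyl, with hydrogen on this oxygen, would compare with methyl. They also leave open whether a longer chain such as propyl, or an ethyl chain ending in an amine, would fall with the other three groups.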